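The compounds below may be only part of what the source reports. "The series", "measured", "known", "first", "only" and "open" are said of these compounds alone.

Measured compounds:
Compound 1, `Cc1nn([C@H](C)c2ccc(Cl)cc2Cl)c2nc(N3CC[C@H](N4CCC[C@H]4CCS(C)(=O)=O)[C@H](C)C3)cnc12`, gives 104 nM in a functional assay on cells for antagonist activity at C-C chemokine receptor type 4 (Homo sapiens), read by fluorescence and calcium flux, with stated times of 2.5 s and 45 s; on this read-out higher numbers stand for weaker inhibition and lower numbers for stronger inhibition.
Compound 2, `Cc1nn([C@H](C)c2ccc(Cl)cc2Cl)c2nc(N3CC[C@H](N4CCC[C@H]4CCC(N)=O)[C@H](C)C3)cnc12`, gives 37 nM in this assay.

Of the two numbers shown, compound 2 gives the lowest; its nearest neighbour is compound 1, and the only measured step is a 2.8-fold lower number from compound 1 to compound 2 (0.45 log units; beyond the scatter), a modest change beyond the scatter that replaces one group with another of similar size on the same chain.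

Compound 3, `Cc1nn([C@H](C)c2ccc(Cl)cc2Cl)c2nc(N3CC[C@H](N4CCC[C@H]4CO)[C@H](C)C3)cnc12`, differs from compound 2 in one place: hydroxy in place of carbamoylmethyl on a saturated chain carbon bound to a saturated ring carbon. This removes the amide carbonyl and nitrogen, leaving a shorter side chain with one hydrogen-bond donor and one acceptor. Within the data shown here, no measured pair covers a change of this kind. The step from compound 1 to compound 2 shows only that swapping one polar end group for another moves the number modestly; it gives no direct guide to shortening the chain and losing the carbamoyl. Compound 3 is therefore expected to sit somewhat weaker than compound 2, with a 2.2-fold higher number from compound 2 to compound 3 (0.33 log units; beyond the scatter) expected, and a wide range. Compound 3 is estimated at 80 nM, between 25 nM and 250 nM.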

Compound 3, half-maximal inhibitory concentration: 32 nM
Compound 3: middle estimate off by 2.5-fold (0.40 log units), on the high side; measured number inside the range.
By their numbers in this assay, from the lowest: compounds 3 and 2 (each within the scatter of the next); then compound 1.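

In this assay, the step of a 1.2-fold lower number from compound 2 to compound 3 (0.06 log units; within the scatter) shows that, on a saturated chain carbon bound to a saturated ring carbon, carbamoylmethyl with its 4 heavy atoms can give way to hydroxy with its 1 heavy atom and the two numbers cannot be told apart; the earlier pair had only compared two end groups on a chain of the same length. The same replacement set against compound 1 gives a 3.3-fold lower number from compound 1 to compound 3 (0.51 log units; beyond the scatter), so compound 1 now stands apart from both other compounds by steps beyond the scatter, and shortening the side chain to hydroxymethyl does not cost activity in this set, where hydroxy and carbamoylmethyl are each counted with 1 hydrogen-bond donor and 1 hydrogen-bond acceptor. Nothing given here explains why these two side chains read alike or why compound 1 stands apart.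

The compounds shown leave open whether a side chain without a hydroxy or carbamoyl end, such as a plain methyl, a methoxymethyl, an aminomethyl or a carboxylic acid, would hold this level. They also leave open how a 2-hydroxyethyl chain would read, which would separate the length of the chain from the group at its end.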